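From 2,4-dichlorophenyl to 3,5-dichlorophenyl

The source may report more compounds than this note shows. Statements on the series, on what has been measured and on what is new or still open speak of the compounds shown alone.

The compounds share one core and differ in the aryl group on a saturated chain carbon bound to an amine nitrogen in a ring. In a functional assay on HeLa cells (Homo sapiens) for antiproliferative activity, with a stated time of 24 h (on this read-out higher numbers stand for weaker inhibition and lower numbers for stronger inhibition), compound 1 `Cc1ccccc1CN1CCc2c(sc(NC(=O)c3ccccc3Cl)c2C(N)=O)C1` gives > 50000 nM, which is a limit of the assay and not a number. Compound 2 `NC(=O)c1c(NC(=O)c2ccccc2Cl)sc2c1CCN(Cc1ccc([N+](=O)[O-])cc1)C2` gives 46100 nM, and compound 3 `NC(=O)c1c(NC(=O)c2ccccc2Cl)sc2c1CCN(Cc1ccc(Cl)cc1Cl)C2` gives 21100 nM, the lower of the two actual numbers.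

Compound 4 `NC(=O)c1c(NC(=O)c2ccccc2Cl)sc2c1CCN(Cc1cc(Cl)cc(Cl)c1)C2` has not been measured. Its difference is 3,5-dichlorophenyl in place of 2,4-dichlorophenyl on a saturated chain carbon bound to an amine nitrogen in a ring: 3,5-dichlorophenyl in place of 2,4-dichlorophenyl, with the same atoms joined differently.

For the measured compounds named here, three measured steps bear on this place. The modest one is a 2.2-fold lower number from compound 2 to compound 3 (0.34 log units; beyond the scatter), the one with an at least modest size is an at least 2.3-fold lower number from compound 1 to compound 3 (0.37 log units; beyond the scatter), and the one whose floor lies within the scatter is an at least 1.0-fold lower number from compound 1 to compound 2 (0.03 log units; that floor lies within the scatter). All three exchange one aryl group for a different one, and none compares two dichlorophenyl groups, so the evidence is indirect.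

Going by the values given here, with a 2.2-fold lower number from compound 2 to compound 3 (0.34 log units; beyond the scatter) as the only step of exact size, no step beyond the scatter is expected in this assay, with a slight lean towards a higher number. The expected step is a 1.3-fold higher number from compound 3 to compound 4 (0.12 log units; within the scatter). For compound 4 the estimated value is 28000 nM, with an expected range from 12000 nM to 50000 nM.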

Compound 4, half-maximal inhibitory concentration: 19600 nM
The estimate for compound 4 lay 1.4-fold (0.15 log units) above the measured number; the range from low to high includes it.
By their numbers in this assay, from the lowest: compounds 4 and 3 (each within the scatter of the next); then compound 2. At a limit, above all of these: compound 1.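

For the compounds shown here, the exchange of 2,4-dichlorophenyl for 3,5-dichlorophenyl is the first comparison of two dichlorophenyl groups at this position, and in this assay it gives a 1.1-fold lower number from compound 3 to compound 4 (0.03 log units; within the scatter), so the arrangement of the two chlorines does not separate these two compounds. Both dichlorophenyl compounds now stand apart from the 4-nitrophenyl compound, with a 2.4-fold lower number from compound 2 to compound 4 (0.37 log units; beyond the scatter) alongside a 2.2-fold lower number from compound 2 to compound 3 (0.34 log units; beyond the scatter). The comparison with the 2-methylphenyl compound, an at least 2.5-fold lower number from compound 1 to compound 4 (0.40 log units; beyond the scatter), gives only a floor, as the value of compound 1 is a limit and not a number: the limit of > 50000 nM in this assay, at which 1 of the 4 values shown sits.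

On these data alone, it remains open whether a carboxylic acid or an amine on this aryl group, or a longer chain between the aryl group and the ring amine nitrogen, would move the number beyond the scatter around compound 3 and compound 4. Also open, as far as these compounds go, is how the read-out would respond to a change elsewhere on the shared core, such as a nitrile in place of the primary carboxamide.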